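From 3-Chlorophenyl to 4-Chlorophenyl on the Sulfonyl Sulfur

A few compounds are considered here, and "the series" means these few. Any claim that something is new, unique, unknown or untested is made for them only; others in the source may bear on it.

In a functional assay on HL-60 cells (Homo sapiens) for antiproliferative activity, read by MTT assay, with a stated time of 72 h (on this read-out lower numbers stand for stronger inhibition and higher numbers for weaker inhibition), compound 1 `CCn1cc(C(=O)O)c(=O)c2cc(F)c(N3CCN(C(=N)NS(=O)(=O)c4cccc(Cl)c4)CC3)cc21` gives 43 nM, level with compound 2 `N=C(NS(=O)(=O)c1cccc(Cl)c1)N1CCN(c2cc3c(cc2F)c(=O)c(C(=O)O)cn3C2CC2)CC1` at 43 nM and compound 3 `N=C(NS(=O)(=O)c1ccccc1C(F)(F)F)N1CCN(c2cc3c(cc2F)c(=O)c(C(=O)O)cn3C2CC2)CC1` at 43 nM. Compound 4 `CCn1cc(C(=O)O)c(=O)c2cc(F)c(N3CCN(C(=N)NS(=O)(=O)c4ccc(Cl)cc4)CC3)cc21` keeps the core of compound 1 and has yet to be measured. The two differ in one place: 4-chlorophenyl in place of 3-chlorophenyl on a sulfonyl sulfur. In words, 4-chlorophenyl stands in place of 3-chlorophenyl on a sulfonyl sulfur.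

Within the data shown here, two measured steps bear on this change. Cyclopropyl in place of ethyl on an aromatic nitrogen gave no change at the digits printed from compound 1 to compound 2 (within the scatter). Replacing the group on the sulfonyl sulfur gave no change at the digits printed from compound 2 to compound 3 (within the scatter), and this second step is the closer precedent, as it alters the same group. Among the measured compounds shown here, no measured compound carries 4-chlorophenyl, so that precedent is only indirect. With neither measured step moving the value, the expected outcome in this assay is a 1.0-fold higher number from compound 1 to compound 4 (0.02 log units; within the scatter), with no shift in either direction expected beyond the scatter. For compound 4 the estimated value is 45 nM, with an expected range of 20 nM to 100 nM.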

Compound 4, half-maximal inhibitory concentration: 43 nM
Estimate against measurement, compound 4: 1.0-fold (0.02 log units) above, and the stated range covers the measured number.
By their numbers in this assay, from the lowest: compounds 1, 2, 3 and 4 (each within the scatter of the next).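

Putting 4-chlorophenyl in place of 3-chlorophenyl on the sulfonyl sulfur, with the core of compound 1 held fixed, gave no change at the digits printed from compound 1 to compound 4 (within the scatter) in this assay. The earlier step on this group, no change at the digits printed from compound 2 to compound 3 (within the scatter), exchanged one substituent for a different one, whereas here the two groups have the same atoms, joined differently. Among the compounds shown, this assay therefore does not separate 3-chlorophenyl from 4-chlorophenyl on the core of compound 1.

The compounds shown leave open whether any group on the sulfonyl sulfur would move the value, such as an unsubstituted phenyl, a 4-methoxyphenyl, a cyclohexyl or a longer alkyl chain. No measurement shown accounts for this result.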